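The source may hold more compounds than are shown below. What is called first, only, known or untested is meant among the compounds shown, and "the series" means these compounds.

Working notes on the series.

Compound 1 `CCCCCCCCCCCCC(C)OC(=O)NC(=O)Oc1c(C(C)C)cccc1C(C)C` is the reference. In an assay on microsomes from intestine for inhibition of acyl-CoA:cholesterol acyltransferase (Oryctolagus cuniculus) (on this read-out lower numbers stand for stronger inhibition and higher numbers for weaker inhibition), compound 1 gives 17 nM. Compound 2 `CCCCCCCCCCCCC(C)(C)OC(=O)NC(=O)Oc1c(C(C)C)cccc1C(C)C` carries methyl in place of hydrogen on a saturated chain carbon bound to an oxygen next to a carbonyl group and two saturated chain carbons relative to compound 1, and in this assay compound 2 gives 21 nM, a step of a 1.2-fold higher number from compound 1 to compound 2 (0.09 log units; within the scatter). Compound 3 `CCCCCCCCCCSC(=O)NC(=O)Oc1c(C(C)C)cccc1C(C)C` has a different core; the difference between the two cores is not broken down here. In this assay compound 3 gives 130 nM, the highest number among the three measured compounds.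

Compound 4 `CCCCCCCCCCCSC(=O)NC(=O)Oc1c(C(C)C)cccc1C(C)C` is not yet measured and differs from compound 3 by methyl in place of hydrogen on a saturated chain carbon, ten or more bonds along the chain from a sulfur. This is the same kind of change as from compound 1 to compound 2, but the place differs: there the methyl enters on a saturated chain carbon bound to an oxygen next to a carbonyl group and two saturated chain carbons, here on a saturated chain carbon along the chain from a sulfur. The change from compound 1 to compound 2 stayed within the scatter, so for compound 4 a step of about a 1.2-fold lower number from compound 3 to compound 4 (0.07 log units; within the scatter) is expected, resting on that earlier step. Compound 4 is therefore estimated at 110 nM in this assay, between 50 nM and 250 nM.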

Compound 4, half-maximal inhibitory concentration: 210 nM
Compound 4: middle estimate off by 1.9-fold (0.28 log units), on the low side, and the stated range covers the measured number.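

In this assay, methyl in place of hydrogen on a saturated chain carbon, ten or more bonds along the chain from a sulfur, gives a 1.6-fold higher number from compound 3 to compound 4 (0.21 log units; within the scatter). Set beside the earlier step, the change reads alike on the two cores: the same change on two cores in this assay, a 1.2-fold higher number (0.09 log units; within the scatter) from compound 1 to compound 2 and a 1.6-fold higher number (0.21 log units; within the scatter) from compound 3 to compound 4, 1.3-fold (0.12 log units) apart, within the scatter of two such steps. This supports carrying a step of small size from one core to the other for this one change, but it rests on a single pair per core, the methyl enters at a different place in each pair, and so the effect of the core is not separated from that of the place.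

Going by these compounds, whether an amine or a carboxylic acid in place of that methyl would also give so small a step remains open. On these data alone, a much shorter chain on either core is equally open.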